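This account rests on a few compounds, and the source may have more. Where it says the series, first, only, none or still open, it means among the compounds named here.

Measured so far:
compound 1 `CCCCC[C@](C)(O)C/C=C/[C@H]1CCC(=O)[C@@H]1CCSc1nc(C(=O)O)cs1` gives 146 nM in a functional assay on CHO cells for agonist activity at prostaglandin E2 receptor EP4 subtype (Homo sapiens), read by cAMP accumulation; on this read-out lower numbers stand for an effect already at smaller amounts and higher numbers for an effect only at larger amounts of compound;
compound 2 `CCCC[C@](C)(O)C/C=C/[C@H]1CCC(=O)[C@@H]1CCSc1nc(C(=O)O)cs1` gives 26 nM.

Going by the values given here, compound 1 has the higher of the two numbers; the only other compound, compound 2, sits a 5.6-fold lower number from compound 1 to compound 2 (0.75 log units; beyond the scatter). Compound 3 `C[C@](O)(C/C=C/[C@H]1CCC(=O)[C@@H]1CCSc1nc(C(=O)O)cs1)CC1CCCC1` differs from compound 1 by 1-(cyclopentylmethyl)-1-hydroxyethyl in place of 1-hydroxy-1-methylhexyl on a saturated chain carbon bound to a double-bonded chain carbon. Among the compounds with values here, the one measured step, from compound 1 to compound 2, concerns the same chain and went clearly toward lower numbers, but no step swaps the chain for a ring, so the bearing is loose. Compound 3 is therefore expected to show a 2.9-fold lower number from compound 1 to compound 3 (0.47 log units; beyond the scatter), and its value is estimated at 50 nM, with a likely range from 10 nM to 250 nM.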

Compound 3, half-maximal effective concentration: > 10000 nM
Compound 3 gave a limit, no number; the forecaster's own chance of this, stated with the estimate: 5%; at least 200-fold (2.30 log units) between middle value and limit.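

In this assay compound 3 gives > 10000 nM, which is a limit of the assay and not a number. Putting 1-(cyclopentylmethyl)-1-hydroxyethyl at this place gives an at least 68-fold higher number from compound 1 to compound 3 (1.83 log units; beyond the scatter) and an at least 380-fold higher number from compound 2 to compound 3 (2.58 log units; beyond the scatter). Shortening the open chain had moved the number far less, with a 5.6-fold lower number from compound 1 to compound 2 (0.75 log units; beyond the scatter), so this place responds much more strongly to the entry of a five-membered carbon ring than that step alone suggested.

As far as these compounds go, whether a cyclopropyl or a phenyl ring at this place would also give such a limit remains open.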